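This account rests on a few compounds, and the source may have more. Where it says the series, first, only, none or still open, it means among the compounds named here.

Measured so far:
compound 1 `COc1ccc(CNc2cc(OC)c(OC)c(OC)c2)cc1Cl`: 46200 nM
compound 2 `C/C=C/C(=O)N(Cc1ccc(OC)c(C)c1)c1cc(OC)c(OC)c(OC)c1`: 14500 nM
compound 3 `COc1ccc(CNc2cc(OC)c(OC)c(OC)c2)cc1C`: 56800 nM

In a functional assay on MGC-803 cells (Homo sapiens) for inhibition, read by MTT assay, with a stated time of 48 h (on this read-out lower numbers stand for stronger inhibition and higher numbers for weaker inhibition), compound 2 gives the lowest number of the three, 14500 nM. Compound 4 `C/C=C/C(=O)N(Cc1ccc(OC)c(Cl)c1)c1cc(OC)c(OC)c(OC)c1` is compound 2 with chloro in place of methyl on an aromatic carbon. The nearest measured evidence is the same swap in reverse, methyl in place of chloro, in a pair without the (prop-1-en-1-yl)carbonyl on nitrogen: a 1.2-fold higher number from compound 1 to compound 3 (0.09 log units; within the scatter). The other step, a 3.9-fold higher number from compound 2 to compound 3 (0.59 log units; beyond the scatter), concerns that carbonyl group, not this swap. One small pair is thin evidence, but no change beyond the scatter is expected here, and the estimated step is a 1.2-fold lower number from compound 2 to compound 4 (0.06 log units; within the scatter). Compound 4 is expected at 12500 nM, within an estimated range of 5500 nM to 28000 nM.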

Compound 4, half-maximal inhibitory concentration: 7100 nM
Beside the measured number, compound 4's estimate is 1.8-fold (0.25 log units) above it; low and high end bracket the measured number.
By their numbers in this assay, from the lowest: compound 4; then compound 2; then compounds 1 and 3 (each within the scatter of the next).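

In this assay, chloro in place of methyl on this aromatic carbon gives a 2.0-fold lower number from compound 2 to compound 4 (0.31 log units; beyond the scatter), a step that compound 1 and compound 3 did not show beyond the scatter. Even so, the swap does not clearly differ between the two cores: the same change on two cores in this assay, a 1.2-fold higher number (0.09 log units; within the scatter) from compound 1 to compound 3 and a 2.0-fold higher number (0.31 log units; beyond the scatter) from compound 4 to compound 2, 1.7-fold (0.22 log units) apart, within the scatter of two such steps

The (prop-1-en-1-yl)carbonyl on nitrogen now also counts with chloro in place, giving a 6.5-fold lower number from compound 1 to compound 4 (0.81 log units; beyond the scatter), and it too behaves alike on both cores: the same change on two cores in this assay, a 3.9-fold higher number (0.59 log units; beyond the scatter) from compound 2 to compound 3 and a 6.5-fold higher number (0.81 log units; beyond the scatter) from compound 4 to compound 1, 1.7-fold (0.22 log units) apart, within the scatter of two such steps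

The compounds shown cover only chloro and methyl at this position, so what fluoro, a nitrile or an amine would give there stays open. So does the effect of a plain acetyl on the nitrogen.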